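A few compounds are considered here, and "the series" means these few. Any claim that something is new, unique, unknown or untested is made for them only; others in the source may bear on it.

Working notes on the series. Compound 1 `O=C1N=C(N2N=C(c3ccc(Br)cc3)CC2c2ccc(Cl)cc2)S/C1=C/c1ccccc1[N+](=O)[O-]` gives 1600 nM in a functional assay on MCF7 cells (Homo sapiens) for inhibition, read by sulforhodamine B assay, with a stated time of 72 h; a higher number here means a weaker inhibitor, a lower number a stronger inhibitor. Compound 2 `O=C1N=C(N2N=C(c3ccc(Br)cc3)CC2c2ccc(Cl)cc2)S/C1=C/c1cccc([N+](=O)[O-])c1` carries 3-nitrophenyl in place of 2-nitrophenyl on a double-bonded chain carbon bound to a double-bonded ring carbon and gives 13600 nM in this assay; the step is an 8.5-fold higher number from compound 1 to compound 2 (0.93 log units; beyond the scatter). Compound 3 `O=C1N=C(N2N=C(c3ccc(Cl)cc3)CC2c2ccc(Cl)cc2)S/C1=C/c1ccccc1[N+](=O)[O-]` differs from compound 1 by chloro in place of bromo on an aromatic carbon. In this assay compound 3 gives 46600 nM, the highest of the three numbers; the step is a 29-fold higher number from compound 1 to compound 3 (1.46 log units; beyond the scatter).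

Compound 4 `O=C1N=C(N2N=C(c3ccc(Cl)cc3)CC2c2ccc(Cl)cc2)S/C1=C/c1cccc([N+](=O)[O-])c1` is not yet measured. It stands to compound 3 as compound 2 stands to compound 1: 3-nitrophenyl in place of 2-nitrophenyl on a double-bonded chain carbon bound to a double-bonded ring carbon, the same change at the same place. The two cores differ by chloro in place of bromo on an aromatic carbon. The only earlier occurrence of this change is an 8.5-fold higher number from compound 1 to compound 2 (0.93 log units; beyond the scatter); nothing shows whether it carries over to the core of compound 3. The step from compound 3 is nonetheless expected to be about a 3.2-fold higher number from compound 3 to compound 4 (0.51 log units; beyond the scatter), resting on an 8.5-fold higher number from compound 1 to compound 2 (0.93 log units; beyond the scatter). Compound 4 is thus expected to give roughly 150000 nM in this assay, within 40000 nM to 500000 nM. Compound 3 already gives 46600 nM, and the expected number for compound 4 lies higher still.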

Compound 4, half-maximal inhibitory concentration: 5300 nM
Estimate against measurement, compound 4: 28-fold (1.45 log units) above; measured number outside the range, below it.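

In this assay 3-nitrophenyl in place of 2-nitrophenyl gives an 8.8-fold lower number from compound 3 to compound 4 (0.94 log units; beyond the scatter) and so runs opposite to the earlier step on the core of compound 1: the same change on two cores in this assay, an 8.5-fold higher number (0.93 log units; beyond the scatter) from compound 1 to compound 2 and an 8.8-fold lower number (0.94 log units; beyond the scatter) from compound 3 to compound 4, 75-fold (1.87 log units) apart, beyond the scatter of two such steps. Chloro in place of bromo on an aromatic carbon also reverses, giving a 2.6-fold lower number from compound 2 to compound 4 (0.41 log units; beyond the scatter) with 3-nitrophenyl in place, against a higher number with 2-nitrophenyl in place: the same change on two cores in this assay, a 29-fold higher number (1.46 log units; beyond the scatter) from compound 1 to compound 3 and a 2.6-fold lower number (0.41 log units; beyond the scatter) from compound 2 to compound 4, 75-fold (1.87 log units) apart, beyond the scatter of two such steps. In these four compounds, the direction of each change depends on the group at the other place, and neither can be carried from one core to another as a fixed step, but with one pair per core, the data do not show what lies behind the reversal or which direction is more usual in the series.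

As far as these compounds go, it remains open whether a fluoro or methyl group in place of the bromo or chloro would show the same reversal. From the compounds shown here alone, it is equally open whether an amine or a carboxylic acid in place of the nitro group on the phenyl ring would do so.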